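Swapping a Cyclohexane Acid for a Hydroxy Sulfone Ring

This account rests on a few compounds, and the source may have more. Where it says the series, first, only, none or still open, it means among the compounds named here.

The shared core of compound 1 `CC[C@]1(C(=O)O)CC[C@H](C(=O)N2CC[C@](c3ccc(C(F)(C(F)(F)F)C(F)(F)F)cc3)(S(=O)(=O)c3ccc(F)cc3)C2)CC1` is carried by an amide whose carbonyl carbon bears a 4-carboxy-4-ethylcyclohexyl group. Two close relatives keep this core: compound 2 `O=C1NC(=O)C2(CCC(C(=O)N3CC[C@](c4ccc(C(F)(C(F)(F)F)C(F)(F)F)cc4)(S(=O)(=O)c4ccc(F)cc4)C3)CC2)N1` and compound 3 `COC(=O)[C@H]1CC[C@H](C(=O)N2CC[C@](c3ccc(C(F)(C(F)(F)F)C(F)(F)F)cc3)(S(=O)(=O)c3ccc(F)cc3)C2)CC1`. Only one of the three has a number in an ADME assay on microsomes from liver (Mus musculus) for metabolic stability, with a stated time of 10 min; on this read-out higher numbers stand for a more stable compound and lower numbers for a less stable compound: compound 2 gives 81%; 82% (2 entries), and its repeated readings agree closely (the several entries of compound 2 in this assay, 81%; 82% (2 entries)). For compound 1 the read-out stands as "not determined" (no result reported), and for compound 3 as "not determined" (no result reported), so compound 1 has no place of its own on the scale yet; the level of compound 2 is the only anchor.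

Compound 4 `O=C(N1CC[C@](c2ccc(C(F)(C(F)(F)F)C(F)(F)F)cc2)(S(=O)(=O)c2ccc(F)cc2)C1)C1(O)CCS(=O)(=O)CC1` differs from compound 1 at the carbonyl carbon whose other neighbour is the amide-type nitrogen in a ring (4-hydroxy-1,1-dioxothian-4-yl in place of 4-carboxy-4-ethylcyclohexyl on a carbonyl carbon).

No measured step between any two of these compounds exists in this assay, so the size of this change cannot be read off. Given that compound 2, with a different group at the same carbonyl, holds a high level 81%; 82% (2 entries), compound 4 is expected to sit near that level, with any departure from it most likely within the usual scatter or a little below. The estimate for compound 4 in this assay is 74%, in a range from 50% to 92%.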

Compound 4, percent of the compound remaining: 90%
Compound 4: the middle estimate sits 16 percentage points below what was measured; measured number inside the range.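

In this assay, within the data shown here, compound 4 gives 90%, but compound 1 has no number on this scale, and no step between compound 1 and compound 4 can be read. From the compounds shown here alone, whether 4-hydroxy-1,1-dioxothian-4-yl in place of 4-carboxy-4-ethylcyclohexyl raises, lowers or leaves unchanged the percent of compound remaining stays open.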